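The source may hold more compounds than are shown below. What is called first, only, known or untested is meant among the compounds shown, and "the series" means these compounds.

Compound 1, `CC1=CSC2=NC(/C=C/c3ccccc3Cl)=C(C(=O)/C=C/c3ccccc3Cl)C(c3ccccc3)N12`, gives 206 ug/mL in an ADME assay on Vero cells (Chlorocebus sabaeus) for cytotoxicity, read by fluorescence and resazurin assay, with a stated time of 72 h; a higher number here means that more compound is tolerated, a lower number that less compound is tolerated.
Compound 2, `CC1=CSC2=NC(/C=C/c3ccc(Br)cc3)=C(C(=O)/C=C/c3ccc(Br)cc3)C(c3ccccc3)N12`, gives 282 ug/mL in this assay.
Compound 3, `CC1=CSC2=NC(/C=C/c3ccccc3Cl)=C(C(=O)/C=C/c3ccccc3Cl)C(c3ccc(Cl)cc3)N12`, gives 430 ug/mL in this assay.

The difference between the cores of compound 1 and compound 2 is not broken down here. Compound 3 differs from compound 1 by chloro in place of hydrogen on an aromatic carbon, and that change gave a 2.1-fold higher number from compound 1 to compound 3 (0.32 log units; beyond the scatter). Compound 4, `CC1=CSC2=NC(/C=C/c3ccc(Br)cc3)=C(C(=O)/C=C/c3ccc(Br)cc3)C(c3ccc(Cl)cc3)N12`, has not yet been measured; it differs from compound 2 by chloro in place of hydrogen on an aromatic carbon, the same change at the same place. Among the compounds with values here, because the change from compound 1 to compound 3 gave a 2.1-fold higher number from compound 1 to compound 3 (0.32 log units; beyond the scatter), a step of similar size is expected from compound 2 to compound 4, estimated as a 1.8-fold higher number from compound 2 to compound 4 (0.27 log units; within the scatter), though with only one earlier instance the expectation is loose. Compound 4 is therefore estimated at 520 ug/mL in this assay, most likely between 290 ug/mL and 950 ug/mL.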

Compound 4, half-maximal cytotoxic concentration: 420 ug/mL
The estimate for compound 4 lay 1.2-fold (0.09 log units) above the measured number, and the stated range covers the measured number.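

On the core of compound 2, phenyl to 4-chlorophenyl gave a 1.5-fold higher number from compound 2 to compound 4 (0.17 log units; within the scatter) in this assay. Set beside the earlier step, the change carries from one core to the other without a difference that can be told apart: the same change on two cores in this assay, a 2.1-fold higher number (0.32 log units; beyond the scatter) from compound 1 to compound 3 and a 1.5-fold higher number (0.17 log units; within the scatter) from compound 2 to compound 4, 1.4-fold (0.15 log units) apart, within the scatter of two such steps. Within the data shown here, this rests on only two pairs, and the second step alone does not clear the scatter, so it shows agreement between these two cores but neither fixes the size of the step nor extends it to any other core.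

The compounds shown leave open how a group other than chloro in this place, such as fluoro, methoxy or an amine, would read in this assay. They also leave open whether chloro would behave alike on cores other than these two.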